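Chain-end carbonyl variations on a shared sulfonamide core

The compounds below may be only part of what the source reports. "The series", "measured", "known", "first", "only" and "open" are said of these compounds alone.

Three compounds share one core and differ only at the end of the saturated chain. Compound 1 `COc1cccc(Sc2c(NS(=O)(=O)c3ccc(C(C)(C)C)cc3)noc2CCCC(=O)O)c1` carries a carboxylic acid and in an assay on COS-7 cells for displacement of a labelled ligand from Endothelin receptor type B (Sus scrofa) (on this read-out higher numbers stand for weaker inhibition and lower numbers for stronger inhibition), compound 1 gives 500 nM. Compound 2 `COc1cccc(Sc2c(NS(=O)(=O)c3ccc(C(C)(C)C)cc3)noc2CCCC(N)=O)c1` carries the primary amide, and in this assay compound 2 gives 240 nM. Compound 3 `COc1cccc(Sc2c(NS(=O)(=O)c3ccc(C(C)(C)C)cc3)noc2CCCC(C)=O)c1` carries a methyl ketone, and in this assay compound 3 gives 400 nM, the second highest of the three numbers, with compound 1 nearest and compound 2 furthest, both within the scatter of compound 3.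

Compound 4 `COc1cccc(Sc2c(NS(=O)(=O)c3ccc(C(C)(C)C)cc3)noc2CCCCC=O)c1` is the next entry, an isomer of compound 3: formylmethyl in place of acetyl on a saturated chain carbon, three bonds along the chain from an aromatic carbon. The measured steps touch the same chain end. Among the measured compounds shown here, the step of a 1.3-fold lower number from compound 1 to compound 3 (0.10 log units; within the scatter) and the step of a 1.7-fold higher number from compound 2 to compound 3 (0.22 log units; within the scatter) sit within the scatter; only the step of a 2.1-fold lower number from compound 1 to compound 2 (0.32 log units; beyond the scatter) is modest and beyond it. For the measured compounds named here, none of them swaps acetyl for formylmethyl, so no direct precedent exists for the change to compound 4; the three numbers together span a narrow band. The expected step is therefore no change at the digits printed from compound 3 to compound 4 (within the scatter), nothing beyond the scatter in this assay. Compound 4 is estimated at 400 nM, with a range from 180 nM to 900 nM.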

Compound 4, half-maximal inhibitory concentration: 20 nM
Compound 4: the middle estimate sits 20-fold (1.30 log units) above what was measured; measured number outside the range, below it.
By their numbers in this assay, from the lowest: compound 4; then compounds 2, 3 and 1 (each within the scatter of the next, the first and the last beyond it).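

Formylmethyl in place of acetyl gives a 20-fold lower number from compound 3 to compound 4 (1.30 log units; beyond the scatter) in this assay, so this chain end is far more sensitive than the earlier compounds indicated, the largest step among them being the modest 2.1-fold lower number from compound 1 to compound 2 (0.32 log units; beyond the scatter) on the same read-out. The other two chain ends compare the same way, with a 12-fold lower number from compound 2 to compound 4 (1.08 log units; beyond the scatter) and a 25-fold lower number from compound 1 to compound 4 (1.40 log units; beyond the scatter) in this assay, which places compound 4 beyond the scatter of all three earlier compounds. The change from 3-acetylpropyl to 4-formylbutyl leaves the heavy atoms, the double bond outside aromatic rings, the hydrogen-bond donors and the hydrogen-bond acceptors as they were, so in this series a rearrangement of the same atoms at the chain end is enough to produce a large step.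

Nothing available accounts for the size of this step.

As far as these compounds go, whether the low number depends on the formyl group itself or also on the length of the chain that carries it stays open, and a shorter or longer chain ending in formyl would separate the two. From the compounds shown here alone, it is equally open how a hydroxymethyl group, a nitrile or an amine at the same chain end would read in this assay on this core.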